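This account rests on a few compounds, and the source may have more. Where it says the series, first, only, none or still open, it means among the compounds named here.

Measured so far in a functional assay, read by spectrophotometry, tested at 100 uM; a higher number here means a weaker inhibitor, a lower number a stronger inhibitor:

Compound 1 `O=C(/C=C/c1cccs1)c1cccc(NC(=O)c2cc(-c3ccncc3)n[nH]2)c1` gives 27600 nM
Compound 2 `COc1ccc(/C=C/C(=O)c2cccc(NC(=O)c3cc(-c4ccncc4)n[nH]3)c2)cc1` gives 38400 nM
Compound 3 `COc1cc(/C=C/C(=O)c2cccc(NC(=O)c3cc(-c4ccncc4)n[nH]3)c2)cc(OC)c1OC` gives 54500 nM

Compound 3 stands within the scatter of both other compounds, with a 2.0-fold higher number from compound 1 to compound 3 (0.30 log units; within the scatter) and a 1.4-fold higher number from compound 2 to compound 3 (0.15 log units; within the scatter) as its steps. Compound 4 `COc1ccccc1/C=C/C(=O)c1cccc(NC(=O)c2cc(-c3ccncc3)n[nH]2)c1` differs from it by 2-methoxyphenyl in place of 3,4,5-trimethoxyphenyl on a double-bonded chain carbon bound to a double-bonded chain carbon and so carries 2-methoxyphenyl in place of 3,4,5-trimethoxyphenyl on a double-bonded chain carbon bound to a double-bonded chain carbon. For the measured compounds named here, no measured compound carries 2-methoxyphenyl, so the evidence is indirect. The remaining measured change at this place, a 1.4-fold higher number from compound 1 to compound 2 (0.14 log units; within the scatter), also stays within the scatter. No step beyond the scatter is therefore expected in this assay, and the estimated step is a 1.4-fold lower number from compound 3 to compound 4 (0.13 log units; within the scatter) as the expected outcome. Compound 4 is estimated at 40000 nM with 20000 nM to 80000 nM as its expected range.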

Compound 4, half-maximal inhibitory concentration: 41700 nM
Compound 4: middle estimate off by 1.0-fold (0.02 log units), on the low side, within the range that was stated.
By their numbers in this assay, from the lowest: compounds 1, 2, 4 and 3 (each within the scatter of the next).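

In this assay, 2-methoxyphenyl on a double-bonded chain carbon bound to a double-bonded chain carbon stays within the scatter of all three earlier groups: 3,4,5-trimethoxyphenyl (a 1.3-fold lower number from compound 3 to compound 4 (0.12 log units; within the scatter)), 4-methoxyphenyl (a 1.1-fold higher number from compound 2 to compound 4 (0.04 log units; within the scatter)) and thiophen-2-yl (a 1.5-fold higher number from compound 1 to compound 4 (0.18 log units; within the scatter)). The pair of compound 2 and compound 4 adds something new, since the same methoxyphenyl group with its methoxy placed differently gives no step beyond the scatter. On these data alone, whether an amine, a carboxylic acid or a longer chain at this place would give a step beyond the scatter remains open. No evidence bears on this result.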